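From Nitro to Amino: Expecting a Value for Compound 4

This account rests on a few compounds, and the source may have more. Where it says the series, first, only, none or still open, it means among the compounds named here.

Of the compounds shown here, three have been measured in a functional assay on HeLa cells (Homo sapiens) for cytotoxicity, read by XTT assay, with a stated time of 72 h; a higher number here means a weaker inhibitor, a lower number a stronger inhibitor. Compound 1 `COc1ccc(Cc2ccc(OC)c(OC)c2OC)cc1[N+](=O)[O-]` gives 32 nM. Compound 2 `COc1ccc(Cc2cc(OC)c(OC)c(OC)c2)cc1[N+](=O)[O-]` gives 300 nM, and compound 3 `CCn1ccc2cc(C(=O)c3ccc(OC)c(OC)c3OC)ccc21` gives 450 nM. Among these three numbers compound 2 stands second highest. Its value and that of compound 3 lie within the usual scatter of each other, so no order between the two can be read, whereas compound 1 has a number lower by a margin beyond the scatter.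

Compound 4 `COc1ccc(Cc2cc(OC)c(OC)c(OC)c2)cc1N` has not yet been measured. It differs from compound 2 in one place: amino in place of nitro on an aromatic carbon. Among the compounds with values here, no pair of measured compounds shows this same change, so there is no measured step to lean on, and the expectation rests on compound 2 alone, with a wide margin of doubt. Compound 4 is expected to give about 120 nM in this assay. Its estimated range runs from 25 nM to 600 nM. The expected step of a 2.5-fold lower number from compound 2 to compound 4 (0.40 log units; beyond the scatter) would point toward a somewhat lower number, only a little beyond the scatter.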

Compound 4, half-maximal inhibitory concentration: 3.2 nM
The estimate for compound 4 lay 38-fold (1.57 log units) above the measured number; measured number below the stated range.
By their numbers in this assay, from the lowest: compound 4; then compound 1; then compounds 2 and 3 (each within the scatter of the next).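

In this assay, amino in place of nitro on this aromatic carbon, ortho to a methoxy group, gives a 94-fold lower number from compound 2 to compound 4 (1.97 log units; beyond the scatter), a large step. Compound 1 and compound 2 both carry nitro here, so they could not show how strongly the number depends on the group at this place. The change takes out three heavy atoms and puts in one, and it brings a hydrogen-bond donor where nitro has none, yet a single step cannot tell which of these differences counts.

Going by these compounds, it remains open whether a methylamino group, an acetamide or a hydroxyl group at this place would give a similarly low number, and whether amino would do the same on the core of compound 1. Nothing available explains why the number falls so far.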